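Linker change on the shared core, working notes

The source may hold more compounds than are shown below. What is called first, only, known or untested is meant among the compounds shown, and "the series" means these compounds.

In a functional assay on SK-BR-3 cells (Homo sapiens) for antiproliferative activity (on this read-out higher numbers stand for weaker inhibition and lower numbers for stronger inhibition), compound 1 `CC(C)=CCc1cc(C(=O)Nc2cc3ccc(Oc4ccc(C(C)(C)C)cc4)c(C)c3oc2=O)ccc1O` gives 68300 nM. Compound 2 `COc1ccc(Nc2ccc3cc(NC(=O)c4ccc(O)c(CC=C(C)C)c4)c(=O)oc3c2C)cc1` reports only a limit in this assay, > 100000 nM, which is the limit noted as the limit of > 100000 nM in this assay, at which 1 of the 2 values shown sits. Within the data shown here, the single measured step, an at least 1.4-fold higher number from compound 1 to compound 2 (0.16 log units; that floor lies within the scatter), carries that floor and sits within the scatter. Compound 3 `COc1ccc(Cc2ccc3cc(NC(=O)c4ccc(O)c(CC=C(C)C)c4)c(=O)oc3c2C)cc1` introduces (4-methoxybenzyl in place of (4-methoxyphenyl)amino on an aromatic carbon). Among the measured compounds shown here, no measured step covers a change of this kind, so the expectation rests on compound 2 standing at the limit. Compound 3 is expected near 100000 nM, within 30000 nM to 300000 nM. The expected step is a number no higher from compound 2 to compound 3 (the limit leaves the size open), none beyond the scatter.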

Compound 3, half-maximal inhibitory concentration: 11100 nM
The estimate for compound 3 lay 9.0-fold (0.95 log units) above the measured number, outside the stated range (below it).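

In this assay, 4-methoxybenzyl in place of (4-methoxyphenyl)amino on this aromatic carbon, ortho to the methyl group, gives an at least 9.0-fold lower number from compound 2 to compound 3 (0.95 log units; beyond the scatter), so this position can respond to the group it carries. The same group in place of 4-(tert-butyl)phenoxy gives a 6.2-fold lower number from compound 1 to compound 3 (0.79 log units; beyond the scatter). The number for compound 2 is a limit of the assay, so the first step has no upper size: the limit of > 100000 nM in this assay, at which 1 of the 3 values shown sits.

From the compounds shown here alone, it remains open whether the carbon link or the group it carries accounts for these steps. A 4-methoxyphenoxy group, an unsubstituted benzyl or a longer chain such as 2-(4-methoxyphenyl)ethyl would help separate the two.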